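Working notes: clearance estimate for compound 3

The source may hold more compounds than are shown below. What is called first, only, known or untested is meant among the compounds shown, and "the series" means these compounds.

Measured so far:
compound 1 `CS(=O)(=O)Nc1ccc(CNC(=O)c2ccc(C3(C(F)(F)F)CC3)cc2)c(Cl)c1`: 7.5 mL.min-1.g-1
compound 2 `CS(=O)(=O)Nc1ccc(CNC(=O)c2ccc(OC(F)(F)F)cc2)c(Cl)c1`: 9.1 mL.min-1.g-1

In an ADME assay on microsomes from liver (Rattus norvegicus, strain Sprague-Dawley) for metabolic stability, read by HPLC, using NADPH, with stated times of 5 min and 60 min, tested at 10 uM (a lower number here means slower removal, a higher number faster removal of the compound), compound 1 gives 7.5 mL.min-1.g-1, the lowest of the two numbers shown, though the step of a 1.2-fold higher number from compound 1 to compound 2 (0.08 log units; within the scatter) is within the scatter; compound 2 gives 9.1 mL.min-1.g-1. Compound 3 `CS(=O)(=O)Nc1ccc(CNC(=O)c2ccc(C3(O)COC3)cc2)c(Cl)c1` differs from compound 1 in one place: 3-hydroxyoxetan-3-yl in place of 1-(trifluoromethyl)cyclopropyl on an aromatic carbon. Among the measured compounds shown here, only the step from compound 1 to compound 2 bears on this change, and it was small; no measured step covers a 3-hydroxyoxetan-3-yl group. No step beyond the scatter is therefore expected, and the direction is open. For compound 3 the estimate is 6 mL.min-1.g-1 (range 3 mL.min-1.g-1 to 12 mL.min-1.g-1). The expected step is a 1.3-fold lower number from compound 1 to compound 3 (0.10 log units; within the scatter).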

Compound 3, intrinsic clearance in microsomes: 5.4 mL.min-1.g-1
For compound 3 the middle estimate is 1.1-fold (0.05 log units) above the measured one; low and high end bracket the measured number.
By their numbers in this assay, from the lowest: compounds 3, 1 and 2 (each within the scatter of the next).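

Among the compounds shown here, on the aromatic carbon para to a large group, 3-hydroxyoxetan-3-yl, the first group here to carry a hydrogen-bond donor, keeps the number in this assay within the scatter of both earlier compounds (a 1.4-fold lower number from compound 1 to compound 3 (0.14 log units; within the scatter); a 1.7-fold lower number from compound 2 to compound 3 (0.23 log units; within the scatter)). Three different groups at this position of the shared core therefore show no step beyond the scatter. Nothing available accounts for this result.

From the compounds shown here alone, whether an amine, a carboxylic acid or a longer chain at this position would give a step beyond the scatter remains open.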